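From Chloro to Amino on a Fused Core

The source may report more compounds than this note shows. Statements on the series, on what has been measured and on what is new or still open speak of the compounds shown alone.

Among the measured compounds shown here, compound 2 `Fc1ccc(Cn2cnc3ncnc(Cl)c32)cc1` is one of two compounds measured in an assay on isolated protein for inhibition of Ca2+/calmodulin-dependent protein kinase II (CaM kinase II) (Rattus norvegicus), tested at 30 uM; a higher number here means more inhibition at the concentration tested (going by the name of the read-out), a lower number less inhibition. In this assay compound 2 gives 8%. Compound 1 `Clc1ncnc2ncn(Cc3ccccc3)c12` differs from it only in that the fluoro of compound 2 is absent, and in this assay compound 1 gives 0%; the step of a number 8 percentage points higher from compound 1 to compound 2 (within the scatter) lies within the scatter, so the two numbers cannot be told apart. Compound 3 `Nc1ncnc2ncn(Cc3ccc(F)cc3)c12` has not yet been measured. It differs from compound 2 in one place: amino in place of chloro on an aromatic carbon. No measured step bears on this change: the only step shown, a number 8 percentage points higher from compound 1 to compound 2 (within the scatter), concerns fluoro in place of hydrogen and was itself within the scatter. Both measured compounds sit near the bottom of the scale, and nothing in the data points in either direction for an exchange of chloro for amino. For compound 3 the expected step of a number 2 percentage points higher from compound 2 to compound 3 (within the scatter) is accordingly one of no size beyond the scatter. Compound 3 is estimated at 10%, within a range from -8% to 35%.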

Compound 3, a percentage reported as inhibition, at one concentration (the size of the read-out at that concentration, not a potency): 8%
Compound 3: the middle estimate sits 2 percentage points above what was measured; measured number inside the range.
By their numbers in this assay, from the lowest: compounds 1, 2 and 3 (each within the scatter of the next).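

In this assay, the exchange of chloro for amino on an aromatic carbon gives no change at the digits printed from compound 2 to compound 3 (within the scatter). Among the compounds shown here, this is the first reading at this position, next to the ring nitrogen, as the earlier step concerned only fluoro in place of hydrogen elsewhere in the molecule. Here amino, with 1 hydrogen-bond donor and 1 hydrogen-bond acceptor, enters where chloro, with 0 of either, leaves, and compound 3 gives 8%, a number that cannot be told apart from that of compound 2. No measurement at hand offers an explanation for this result.

The compounds shown leave open whether another group at this position, such as a methylamino, a methoxy, a longer amine chain or a carboxylic acid, would give a step beyond the scatter in this assay. They also leave open whether amino would give a similar number with hydrogen in place of the fluoro, since the amino group has been read here only alongside fluoro.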